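The source may report more compounds than this note shows. Statements on the series, on what has been measured and on what is new or still open speak of the compounds shown alone.

Series notes, cytotoxicity on prostate carcinoma cells.

The compounds share a bicyclic core carrying a chlorobenzyl-type arm. Compound 1 `ClCc1ccc(Cn2cnc3c(Cl)ncnc32)cc1` and compound 2 `Nc1nc(Cl)c2ncn(Cc3cccc(CCl)c3)c2n1` have been measured in a functional assay on DU-145 cells (Homo sapiens) for cytotoxicity, read by sulforhodamine B assay, with a stated time of 48 h; a lower number here means that less compound is tolerated, a higher number that more compound is tolerated: compound 1 gives 36300 nM, and compound 2 gives 40700 nM. These two values fall within the scatter of each other, so no order can be read from them. Compound 3 `ClCc1ccc(Cn2cnc3ncnc(Cl)c32)cc1` is an isomer of compound 1 and was taken through the same assay, but in this assay compound 3 gives "not determined" (no result reported), so compound 3 stands without a number in this assay and cannot be placed against compound 1 or compound 2.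

Compound 4 `ClCc1ccc(Cn2cnc3nc(Cl)nc(Cl)c32)cc1` is reached from compound 3 by chloro in place of hydrogen on an aromatic carbon. Going by the values given here, the change is small, a single heavy atom added on the core; nothing in the measured pairs bears on it, since no two measured compounds differ in one place. Given that compound 1 and compound 2 sit close together despite differing in more than one place, the expectation for this assay is a step of no more than the usual scatter from compound 3 to compound 4, in no clear direction. The value expected for compound 4 in this assay is 35000 nM, with a range from 10000 nM to 120000 nM.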

Compound 4, concentration lethal to 50% of the cells: 6600 nM
Compound 4: the middle estimate sits 5.3-fold (0.72 log units) above what was measured, outside the stated range (below it).
By their numbers in this assay, from the lowest: compound 4; then compounds 1 and 2 (each within the scatter of the next).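

Going by these compounds alone, compound 3 has no number in this assay, so no step to compound 4 (6600 nM) can be read from this result. Nothing at hand accounts for the value of compound 4. The compounds shown leave open what the chloro group alone contributes in this assay, as no two measured compounds differ in one place.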